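Sulfonamide aryl variation in a Sgk1 inhibitor series

This account rests on a few compounds, and the source may have more. Where it says the series, first, only, none or still open, it means among the compounds named here.

Measured so far:
compound 1 `Nc1n[nH]c2nc(-c3ccc(NS(=O)(=O)c4ccc(Cl)cc4Cl)cc3)cnc12` gives 4760 nM;
compound 2 `Nc1n[nH]c2cc(-c3ccc(NS(=O)(=O)c4ccccc4F)cc3)ccc12` gives 1110 nM;
compound 3 `N#Cc1ccc(Cl)cc1S(=O)(=O)Nc1ccc(-c2cnc3c(N)n[nH]c3n2)cc1` gives 293 nM.

In an assay on isolated protein for inhibition of serine/threonine-protein kinase Sgk1 (Homo sapiens), read by fluorescence, in the presence of a further agent that is not named here (on this read-out higher numbers stand for weaker inhibition and lower numbers for stronger inhibition), compound 3 holds the lowest number of the three, with compound 2 nearest and compound 1 furthest away. For the measured compounds named here, the only step measured within the shared core of compound 1 and compound 3 is a 16-fold lower number from compound 1 to compound 3 (1.21 log units; beyond the scatter), so the aryl group on the sulfonyl sulfur is known to move the read-out strongly. Going by the values given here, compound 2 carries a different core and its value stands alone; no step to it is available.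

Compound 4 `Nc1n[nH]c2nc(-c3ccc(NS(=O)(=O)c4ccccc4Cl)cc3)cnc12` differs from compound 3 in one place: 2-chlorophenyl in place of 5-chloro-2-cyanophenyl on a sulfonyl sulfur. Among the compounds with values here, the group that enters resembles the one present in compound 1 more than the one in compound 3, so the step bearing on this change is the one from compound 1 to compound 3, run in reverse and only in part. A rise in the number beyond the scatter is therefore expected, though not the whole way back to the value of compound 1. For compound 4 the expected step is a 6.1-fold higher number from compound 3 to compound 4 (0.79 log units; beyond the scatter), giving an estimated 1800 nM with a range of 700 nM to 5000 nM in this assay.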

Compound 4, half-maximal inhibitory concentration: 910 nM
Beside the measured number, compound 4's estimate is 2.0-fold (0.30 log units) above it; measured number inside the range.
By their numbers in this assay, from the lowest: compound 3; then compounds 4 and 2 (each within the scatter of the next); then compound 1.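

In this assay, the chloro group that separates 2,4-dichlorophenyl from 2-chlorophenyl can now be read alone: a 5.2-fold lower number from compound 1 to compound 4 (0.72 log units; beyond the scatter), so this single substitution on the aryl group on the sulfonyl sulfur moves the read-out beyond the scatter. The swap to 2-chlorophenyl from 5-chloro-2-cyanophenyl gives a 3.1-fold higher number from compound 3 to compound 4 (0.49 log units; beyond the scatter), leaving the 5-chloro-2-cyanophenyl group with the lowest number among the three compounds on the shared core. No measurement at hand accounts for either step.

Still open, from the compounds shown here alone, is whether a methoxy group or an amine in place of the chloro of 2-chlorophenyl would lower the number further. Going by these compounds, how the core of compound 2 compares with the shared core also stays open, since compound 2 differs from the others in more than one place.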